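Amide-aryl variation on a shared core: notes toward compound 4

A few compounds are considered here, and "the series" means these few. Any claim that something is new, unique, unknown or untested is made for them only; others in the source may bear on it.

Measured so far:
compound 1 `O=C(CSc1nc(Nc2ccccc2)c2ccccc2n1)Nc1ccccc1Br` gives 10300 nM
compound 2 `O=C(CSc1nc(Nc2ccccc2)c2ccccc2n1)Nc1cccc(F)c1` gives 6790 nM
compound 3 `O=C(CSc1nc(Nc2ccccc2)c2ccccc2n1)Nc1cccc(Cl)c1` gives 8460 nM

All three numbers come from a functional assay on NCI-H1975 cells (Homo sapiens) for inhibition, read by MTT assay, with a stated time of 72 h; a higher number here means a weaker inhibitor, a lower number a stronger inhibitor. Compound 2 holds the lowest of the three, but neither neighbour is separated from it by more than the usual scatter: the nearest step is a 1.2-fold higher number from compound 2 to compound 3 (0.10 log units; within the scatter), the furthest is a 1.5-fold lower number from compound 1 to compound 2 (0.18 log units; within the scatter). The third step, a 1.2-fold lower number from compound 1 to compound 3 (0.09 log units; within the scatter), is likewise within the scatter. No ordering among compounds 1, 2 and 3 can be read from these data.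

Compound 4 `CCc1cccc(NC(=O)CSc2nc(Nc3ccccc3)c3ccccc3n2)c1` differs from compound 2 in one place: ethyl in place of fluoro on an aromatic carbon. Among the compounds with values here, the steps that bear on this change are those that vary the substituent on the amide-type aryl ring, above all the exchange of one halogen for another at the same place in the step from compound 2 to compound 3, and the two steps from compound 1. Every one of them stayed within the scatter. Within the data shown here, no measured pair tests an alkyl group on this ring, so the ethyl group has no direct precedent here, and the estimate for compound 4 leans on the flatness of the three steps. The expected step in this assay is therefore a 1.0-fold higher number from compound 2 to compound 4 (0.01 log units; within the scatter), with no direction beyond the scatter. Compound 4 is estimated at 7000 nM, within a range of 3000 nM to 16000 nM.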

Compound 4, half-maximal inhibitory concentration: 12000 nM
Estimate against measurement, compound 4: 1.7-fold (0.23 log units) below; low and high end bracket the measured number.
By their numbers in this assay, from the lowest: compounds 2, 3, 1 and 4 (each within the scatter of the next).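

Working notes on the amide-aryl ring: the first alkyl group at this place, ethyl on an aromatic carbon meta to a large group, extends the range of substituents tested beyond halogens, yet in this assay its exchange for fluoro (a 1.8-fold higher number from compound 2 to compound 4 (0.25 log units; within the scatter)) and for chloro (a 1.4-fold higher number from compound 3 to compound 4 (0.15 log units; within the scatter)) both stay within the scatter. The exchange that alters both the substituent and its place on the ring, 3-ethylphenyl in place of 2-bromophenyl (a 1.2-fold higher number from compound 1 to compound 4 (0.07 log units; within the scatter)), likewise stays within the scatter, so the flatness seen among the three halogen compounds now also holds with a group of carbon atoms on this ring, and still no ordering among the four compounds can be read. Nothing in the available data offers an explanation for these numbers.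

Open, on these data alone, is whether any group on this ring can move the number beyond the scatter, for example a primary amine, a carboxylic acid or a longer chain such as hexyl. Also open is whether the flatness extends to the remainder of the shared core, which carries no variation in the compounds shown.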